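Cyano for trifluoromethyl on the aryl of compound 2

The source may report more compounds than this note shows. Statements on the series, on what has been measured and on what is new or still open speak of the compounds shown alone.

Measured so far in a functional assay on cells (T-cell, Homo sapiens) for inhibition; on this read-out higher numbers stand for weaker inhibition and lower numbers for stronger inhibition:
compound 1, `CCOc1nc(N)nc2ncc(-c3ccc(OC)cc3)nc12`: > 10000 nM
compound 2, `CCOc1nc(N)nc2ncc(-c3ccc(C(F)(F)F)cc3)nc12`: 10000 nM

Working notes. Compound 1 in this assay gives only a limit, > 10000 nM. Within the data shown here, compound 2 in this assay gives 10000 nM, the only proper number in the set. The value of compound 1 is a limit, so compound 2 has no measured neighbour to be ordered against. Among the measured compounds shown here, the one step measured, a number no higher from compound 1 to compound 2 (the limit leaves the size open), runs into the limit of > 10000 nM in this assay, at which 1 of the 2 values shown sits, and its size is not readable.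

Compound 3, `CCOc1nc(N)nc2ncc(-c3ccc(C#N)cc3)nc12`, is not yet measured. It differs from compound 2 by cyano in place of trifluoromethyl on an aromatic carbon. For the measured compounds named here, no measured step bears directly on a cyano; the one step available, from a methoxy to a trifluoromethyl, is bounded by a limit and gives no size. Both measured values sit at or beyond the weak end of the assay, so a large shift in either direction has nothing to rest on. The expected step is no change at the digits printed from compound 2 to compound 3 (within the scatter), none beyond the scatter. Compound 3 is therefore expected at about 10000 nM, in a range from 3000 nM to 30000 nM, with a fair chance that only a limit is reported.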

Compound 3, half-maximal inhibitory concentration: > 10000 nM
Compound 3 gave a limit, no number (the forecaster's own chance of this, stated with the estimate: 55%); the middle value lies on the limit itself.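

In this assay, cyano in place of trifluoromethyl on an aromatic carbon gives a number no lower from compound 2 to compound 3 (the limit leaves the size open), so this second change at the position brings no sign of stronger inhibition than compound 2 shows. The step from compound 1 to compound 3 joins two limits and cannot be read. With methoxy, trifluoromethyl and cyano now tried at this place, a group carrying a hydrogen-bond acceptor has also been seen there, yet the only proper number remains that of compound 2, and the series gathers at one end of the read-out: the limit of > 10000 nM in this assay, at which 2 of the 3 values shown sit.

As far as these compounds go, whether any group at this place can bring compound 2, at 10000 nM, clearly into the readable range stays open, as does the true size of both limited steps. An amine or a carboxylic acid on the same aromatic carbon would test this position with groups quite unlike the three shown, and a number for either would give the series its first step of readable size.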